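The compounds below may be only part of what the source reports. "The series", "measured", "known", "first", "only" and "open" are said of these compounds alone.

Measured compounds:
compound 1, `Cc1ccc2c(c1)C(=O)C(=O)N2CCCOC(=O)c1cn(C2CC2)c2cc(N3CCN(CCCN4C(=O)C(=O)c5cc(C)ccc54)CC3)c(F)cc2c1=O`, giving 64 ug/mL
compound 2, `CO/N=C1\C(=O)N(CCCN2CCN(c3cc4c(cc3F)c(=O)c(C(=O)OCCCN3C(=O)/C(=N/OC)c5cc(C)ccc53)cn4C3CC3)CC2)c2ccc(C)cc21`, giving 16 ug/mL
compound 3, `CCO/N=C1\C(=O)N(CCCN2CCN(c3cc4c(cc3F)c(=O)c(C(=O)O)cn4C3CC3)CC2)c2ccc(C)cc21`, giving 128 ug/mL

The three measured compounds were tested in an ADME assay on Vero cells (Chlorocebus sabaeus) for cytotoxicity, read by MTT assay, with a stated time of 72 h; a higher number here means that more compound is tolerated, a lower number that less compound is tolerated. Compound 3 has the highest of the three numbers in this assay. Its number sits close to that of compound 1, a gap that lies within the scatter of repeated measurements, so no order between compound 1 and compound 3 can be claimed. Against compound 2 the gap is wider and lies beyond the scatter, so compound 3 is tolerated at a higher concentration than compound 2.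

Compound 4, `CO/N=C1\C(=O)N(CCCN2CCN(c3cc4c(cc3F)c(=O)c(C(=O)O)cn4C3CC3)CC2)c2ccc(C)cc21`, has not yet been measured in this assay. It differs from compound 3 in one place: hydrogen in place of methyl on a saturated chain carbon bound to an oxygen on an unsaturated carbon. Among the measured compounds shown here, no step between any two measured compounds is available to say what such a change does, so the expectation rests on the small size of the change alone. A step of no size beyond the scatter is expected in this assay, in either direction, so that the expected step from compound 3 to compound 4 is no change at the digits printed from compound 3 to compound 4 (within the scatter). Compound 4 is therefore estimated at 128 ug/mL, within a range from 64 ug/mL to 256 ug/mL.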

Compound 4, half-maximal cytotoxic concentration: 256 ug/mL
Estimate against measurement, compound 4: 2.0-fold (0.30 log units) below; measured number inside the range.
By their numbers in this assay, from the lowest: compound 2; then compounds 1, 3 and 4 (each within the scatter of the next, the first and the last beyond it).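

Among the compounds shown here, compound 3 and compound 4 form the first pair here that differs in one place, so the change can now be read directly. In this assay, for the compounds shown here, hydrogen in place of methyl on a saturated chain carbon bound to an oxygen on an unsaturated carbon, the same difference as ethoxy to methoxy, gives a 2.0-fold higher number from compound 3 to compound 4 (0.30 log units; within the scatter) and so shows no step that can be told from the scatter at this position, on this one pair. Nothing shown gives a reason for the size of this step, so the result stands as an observation only.

The compounds shown leave open whether a longer chain at this place, such as propoxy or butoxy, or a ring-bearing group such as benzyloxy, would stay within the scatter of compound 4 or move beyond it. Going by these compounds alone, they also leave open whether hydrogen in place of methyl at this place would give a similarly small step on a different scaffold, such as the one carried by compound 2.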